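Halophenyl swap on the shared core: compound 3 to compound 4

A few compounds are considered here, and "the series" means these few. Any claim that something is new, unique, unknown or untested is made for them only; others in the source may bear on it.

Measured so far in a functional assay on the whole organism (strain Wistar albino) for inhibition, with Rattus norvegicus as the target, read by paw edema, with stated times of 30 min and 1 h, at a dose of 20 mg/kg by the oral route; on this read-out lower numbers stand for less inhibition and higher numbers for more inhibition at the one dose given (going by the name of the read-out):
compound 1 `Cc1nn2c(C(C)c3ccc(CC(C)C)cc3)nnc2s1` gives 43%.
compound 2 `CCCc1nn2c(C(C)c3ccc(CC(C)C)cc3)nnc2s1` gives 15%.
compound 3 `CC(C)Cc1ccc(C(C)c2nnc3sc(-c4ccc(Br)cc4)nn23)cc1` gives 58%.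

Compound 3 stands highest of the three numbers, and its steps to both others lie beyond the scatter: a number 15 percentage points higher from compound 1 to compound 3 (beyond the scatter) and a number 43 percentage points higher from compound 2 to compound 3 (beyond the scatter). Compound 4 `CC(C)Cc1ccc(C(C)c2nnc3sc(-c4ccccc4Cl)nn23)cc1` differs from compound 3 by 2-chlorophenyl in place of 4-bromophenyl on an aromatic carbon. For the measured compounds named here, no measured step exchanges one halophenyl for another; the two steps that reach this carbon replace a chain by 4-bromophenyl, and the chain-to-chain step a number 28 percentage points lower from compound 1 to compound 2 (beyond the scatter) does not touch an aromatic ring at all. With the aromatic ring retained and only the halogen and its substitution pattern altered, the change in this assay is expected to be small, perhaps a slight drop, a number 8 percentage points lower from compound 3 to compound 4 (within the scatter). Compound 4 is therefore estimated at 50%, with a range of 35% to 65%.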

Compound 4, a percentage reported as inhibition, in the whole organism at one dose (the size of the read-out at that dose, not a potency): 43%
The estimate for compound 4 lay 7 percentage points above the measured number, within the range that was stated.
By their numbers in this assay, from the lowest: compound 2; then compounds 1 and 4 (each within the scatter of the next); then compound 3.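

In this assay this aromatic carbon distinguishes between aryl groups: exchanging one halophenyl for the other gives a number 15 percentage points lower from compound 3 to compound 4 (beyond the scatter) and so the gain seen with 4-bromophenyl does not extend to every halophenyl. An aryl group here is not sufficient to separate from methyl, with no change at the digits printed from compound 1 to compound 4 (within the scatter) as the reading, while against propyl the 2-chlorophenyl group still gives a number 28 percentage points higher from compound 2 to compound 4 (beyond the scatter) in this series. No available evidence explains the difference between the two halophenyl groups.

Halogen and its place on the phenyl ring change together in this step, so their contributions cannot be separated. On these data alone, whether 4-chlorophenyl or a phenyl ring carrying an amine would match compound 3 remains open.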